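From methyl to chloro in a small cytotoxic pair

The source may hold more compounds than are shown below. What is called first, only, known or untested is meant among the compounds shown, and "the series" means these compounds.

Compound 1 `O=C(CN1CCN(c2cc(=O)[nH]c3ccc(F)cc23)CC1)Nc1nc(-c2ccccc2)cs1` gives 7200 nM here
Compound 2 `Cc1ccc(-c2csc(NC(=O)CN3CCN(c4cc(=O)n(-c5ccccc5)c5ccccc45)CC3)n2)cc1` gives 16500 nM here

In a functional assay on T47D cells (Homo sapiens) for cytotoxicity, read by MTT assay, with a stated time of 3 h (on this read-out higher numbers stand for weaker inhibition and lower numbers for stronger inhibition), compound 2 at 16500 nM has the higher of the two numbers, meaning weaker inhibition, and its gap to compound 1 lies beyond the usual scatter. Compound 3 `O=C(CN1CCN(c2cc(=O)n(-c3ccccc3)c3ccccc23)CC1)Nc1nc(-c2ccc(Cl)cc2)cs1` differs from compound 2 in one place: 4-methylphenyl becomes 4-chlorophenyl, with chloro in place of methyl on an aromatic carbon. Going by the values given here, no measured pair shows this change alone, so the expectation rests on compound 2 at 16500 nM as the starting point. In this assay the expected change is small, with a 1.2-fold lower number from compound 2 to compound 3 (0.07 log units; within the scatter) as the estimate and nothing beyond the scatter. The estimate for compound 3 is 14000 nM (expected range 6000 nM to 32000 nM).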

Compound 3, half-maximal inhibitory concentration: 30200 nM
Compound 3: the middle estimate sits 2.2-fold (0.33 log units) below what was measured, within the range that was stated.
By their numbers in this assay, from the lowest: compound 1; then compounds 2 and 3 (each within the scatter of the next).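

In this assay chloro in place of methyl on an aromatic carbon gives a 1.8-fold higher number from compound 2 to compound 3 (0.26 log units; within the scatter) and so, at this position, the two groups cannot be told apart. Going by these compounds alone, this is the first direct look at this position, and here a carbon swapped for a chlorine leaves the read-out within its usual noise. No measurement shown here offers an explanation for the result.

On these data alone, whether a different group at this position, such as an amine or a carboxylic acid, would move the number beyond the scatter remains open. So does whether chloro in place of methyl behaves the same way on another core.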